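Taking the Benzyl Group Off Compound 2

This account rests on a few compounds, and the source may have more. Where it says the series, first, only, none or still open, it means among the compounds named here.

In a functional assay on T47D cells (Homo sapiens) for antiproliferative activity, read by MTT assay, with a stated time of 48 h (on this read-out lower numbers stand for stronger inhibition and higher numbers for weaker inhibition), compound 1 `O=C(c1ccccc1)c1ccc2[nH]c(-c3cc4ccccc4n3Cc3ccccc3)nc2c1` has no number ("not determined" (no result reported)). Within the data shown here, that leaves compound 2 `Brc1ccc2[nH]c(-c3cc4ccccc4n3Cc3ccccc3)nc2c1` with the only measured value (15500 nM), so it cannot yet be ranked against anything. Compound 3 `Brc1ccc2[nH]c(-c3cc4ccccc4[nH]3)nc2c1` carries hydrogen in place of benzyl on an aromatic nitrogen and is otherwise the same. Among the measured compounds shown here, no measured pair shows what this change does, so the expectation is loose: a modest weakening in this assay with an estimated 1.9-fold higher number from compound 2 to compound 3 (0.29 log units; within the scatter) (higher numbers mean weaker inhibition). Compound 3 is expected at about 30000 nM (estimated range 10000 nM to 90000 nM).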

Compound 3, half-maximal inhibitory concentration: 4990 nM
Beside the measured number, compound 3's estimate is 6.0-fold (0.78 log units) above it; the whole stated range lies above it.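

In this assay, replacing benzyl with hydrogen on the aromatic nitrogen gives a 3.1-fold lower number from compound 2 to compound 3 (0.49 log units; beyond the scatter) and so moves the number toward stronger inhibition. Among these compounds, this is the first measured sign that this position responds to a change, and the benzyl group is not required for activity in this pair. Nothing available gives a reason for this drop.

As far as these compounds go, whether a small methyl group or a longer chain ending in an amine on this nitrogen would give a lower or higher number remains open. So does whether the same step holds with a group other than bromine on the core.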